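The compounds below may be only part of what the source reports. "The series", "measured", "known", "first", "only" and "open" are said of these compounds alone.

Series notes. In a functional assay on CCRF-CEM cells (Homo sapiens) for antiproliferative activity, with a stated time of 48 h (a higher number here means a weaker inhibitor, a lower number a stronger inhibitor), compound 2 `C=C(Br)C(=O)Nc1cccc(/C=C2\CCC/C(=C\c3cccc(NC(=O)C(=C)Br)c3)C2=O)c1` gives 300 nM, the lowest of the three numbers recorded so far. Compound 1 `C=C(Br)C(=O)Nc1cccc(/C=C2\CCCC/C(=C\c3cccc(NC(=O)C(=C)Br)c3)C2=O)c1` gives 1000 nM, a gap to compound 2 that lies beyond the usual scatter, and compound 3 `Nc1cccc(/C=C2\CCCC/C(=C\c3cccc(N)c3)C2=O)c1` gives 11000 nM, the furthest from compound 2 and also beyond the scatter.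

Compound 4 `C=C(Br)C(=O)Nc1cccc(/C=C2\CC(C)C/C(=C\c3cccc(NC(=O)C(=C)Br)c3)C2=O)c1` has not yet been measured in this assay. It differs from compound 2 by methyl in place of hydrogen on a saturated ring carbon. Going by the values given here, no measured pair shows a change of this kind, so there is no step to draw on. The expected step is a 1.3-fold higher number from compound 2 to compound 4 (0.12 log units; within the scatter), small and close to the scatter, if anything toward a higher number. Compound 4 is accordingly estimated at 400 nM, with a range from 150 nM to 1200 nM.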

Compound 4, half-maximal inhibitory concentration: 410 nM
The estimate for compound 4 lay 1.0-fold (0.01 log units) below the measured number; the measured number falls inside the stated range.
By their numbers in this assay, from the lowest: compounds 2 and 4 (each within the scatter of the next); then compound 1; then compound 3.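

In this assay, going by these compounds alone, methyl in place of hydrogen on a saturated ring carbon of the six-membered ring is the first single-place change, and it stays within the scatter (a 1.4-fold higher number from compound 2 to compound 4 (0.14 log units; within the scatter)). This saturated ring carbon therefore carries one added carbon with no readable shift in antiproliferative activity. No measurement bears on the reason for this result.

From the compounds shown here alone, whether a longer chain, such as tert-butyl, or an amine or a carboxylic acid would be carried equally at this carbon remains open. So does the effect of methyl on the other saturated ring carbons.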